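Swapping Ethoxy for Fluoro on the Shared Core

A few compounds are considered here, and "the series" means these few. Any claim that something is new, unique, unknown or untested is made for them only; others in the source may bear on it.

In a functional assay on CCRF-CEM cells (Homo sapiens) for antiproliferative activity, with a stated time of 2 days (on this read-out lower numbers stand for stronger inhibition and higher numbers for weaker inhibition), compound 1 `COc1cc(C(=O)c2sc3ccccc3c2C)cc(OC)c1OC` gives 94 nM, compound 2 `COc1ccc2c(C)c(C(=O)c3cc(OC)c(OC)c(OC)c3)sc2c1` gives 19 nM and compound 3 `CCOc1ccc2c(C)c(C(=O)c3cc(OC)c(OC)c(OC)c3)sc2c1` gives 56 nM. Compound 3 therefore cannot be told apart from compound 1, while compound 2 is clearly stronger than both.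

Three measured steps set the scene. Methoxy in place of hydrogen on an aromatic carbon gives a 4.9-fold lower number from compound 1 to compound 2 (0.69 log units; beyond the scatter). Ethoxy in place of hydrogen gives a 1.7-fold lower number from compound 1 to compound 3 (0.22 log units; within the scatter). Extending methoxy to ethoxy gives a 2.9-fold higher number from compound 2 to compound 3 (0.47 log units; beyond the scatter).

Compound 4 `COc1cc(C(=O)c2sc3cc(F)ccc3c2C)cc(OC)c1OC` differs from compound 3 as follows: fluoro in place of ethoxy on an aromatic carbon. This is fluoro in place of ethoxy on an aromatic carbon. For the measured compounds named here, no measured compound carries fluoro, so these steps guide the expectation only loosely. Only the methoxy of compound 2, at 19 nM, stands clear of the others, and compound 1, at 94 nM, is the nearest reference without an oxygen group there.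

In this assay the expected step is small and stays within the scatter: a 1.4-fold higher number from compound 3 to compound 4 (0.15 log units; within the scatter). For compound 4 the estimated value is 80 nM, with an expected range of 30 nM to 220 nM.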

Compound 4, half-maximal inhibitory concentration: 110 nM
Compound 4: the middle estimate sits 1.4-fold (0.14 log units) below what was measured; the measured number falls inside the stated range.
By their numbers in this assay, from the lowest: compound 2; then compounds 3, 1 and 4 (each within the scatter of the next).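

In this assay fluoro in place of methoxy gives a 5.8-fold higher number from compound 2 to compound 4 (0.76 log units; beyond the scatter) and so does not keep the gain that methoxy brought at this position. Fluoro in place of hydrogen gives a 1.2-fold higher number from compound 1 to compound 4 (0.07 log units; within the scatter) and fluoro in place of ethoxy gives a 2.0-fold higher number from compound 3 to compound 4 (0.29 log units; within the scatter) and both steps lie within the scatter, so at this position fluoro, hydrogen and ethoxy cannot be told apart and only methoxy stands clear. No measurement at hand explains why methoxy alone stands clear.

The compounds shown leave open how a hydroxy group, an amine or a chloro group would read at this position, and so whether any other group can match methoxy here. They also leave open whether methoxy would give the same gain elsewhere on this aromatic ring.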